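Swapping phenoxy for methylsulfonyl under a shared limit

The source may report more compounds than this note shows. Statements on the series, on what has been measured and on what is new or still open speak of the compounds shown alone.

Measured in an ADME assay on HepG2 cells (Homo sapiens) for cytotoxicity, read by luminescence, with a stated time of 72 h; on this read-out lower numbers stand for an effect already at smaller amounts and higher numbers for an effect only at larger amounts of compound:
- Compound 1 `CCOC(=O)c1c(-c2ccccc2)[nH]c2cc(OC)ccc2c1=O`: > 21500 nM
- Compound 2 `CCCCOc1cccc(-c2[nH]c3cc(OC)ccc3c(=O)c2C(=O)OCC)c1`: > 21500 nM
- Compound 3 `CCOC(=O)c1c(-c2cccc(Oc3ccccc3)c2)[nH]c2cc(OC)ccc2c1=O`: > 21500 nM

Each of these entries is a limit of the assay and not a number. Compound 3 therefore has no exact value, only the limit > 21500 nM. All three compounds share (the limit of > 21500 nM in this assay, at which 3 of the 3 values shown sit).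

The next compound, compound 4 `CCOC(=O)c1c(-c2cccc(S(C)(=O)=O)c2)[nH]c2cc(OC)ccc2c1=O`, keeps the shared core and changes one group: methylsulfonyl in place of phenoxy on an aromatic carbon. In words, methylsulfonyl takes the place of phenoxy on an aromatic carbon.

For the measured compounds named here, three measured steps concern a group on an aromatic ring. Butoxy in place of hydrogen gives a step that the two limits leave unreadable from compound 1 to compound 2. Phenoxy in place of hydrogen gives a step that the two limits leave unreadable from compound 1 to compound 3. Phenyl in place of butyl on the oxygen gives a step that the two limits leave unreadable from compound 2 to compound 3. None of these steps has a readable size, so they point in no direction. Going by the values given here, no measured compound carries a methylsulfonyl group. The expectation is therefore no change beyond the usual scatter, and the estimated step is a step that the limit leaves unreadable from compound 3 to compound 4.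

In this assay, compound 4 is estimated at 30000 nM, with an expected range from 20000 nM to 60000 nM.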

Compound 4, half-maximal effective concentration: > 21500 nM
Compound 4 ended at the assay's limit; the forecaster's own chance of this, stated with the estimate: 90%; the middle value lies beyond the limit too.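

Compound 4 sits at the same limit of the assay as compound 1, compound 2 and compound 3, so no step among these four compounds can be read in this assay: the limit of > 21500 nM in this assay, at which 4 of the 4 values shown sit. The compounds shown leave open whether hydrogen, butoxy, phenoxy or methylsulfonyl on that aromatic carbon makes any difference to cytotoxicity, and at what concentration any of them would show an effect.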